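A few compounds are considered here, and "the series" means these few. Any claim that something is new, unique, unknown or untested is made for them only; others in the source may bear on it.

Compound 1 `c1ccc(-c2cc(-c3ccsc3)cc(-c3ccccn3)n2)nc1`: 0.0017 ug/mL
Compound 2 `c1ccc(-c2cc(-c3cccs3)cc(-c3ccncc3)n2)nc1`: 0.22 ug/mL
Compound 3 `c1ccc(-c2cc(-c3ccsc3)cc(-c3cccnc3)n2)nc1`: 0.054 ug/mL

These three compounds were tested in a functional assay on PC-3 cells (Homo sapiens) for antiproliferative activity; a lower number here means a stronger inhibitor of growth, a higher number a weaker inhibitor of growth. Compound 1 gives the lowest number of the three; compound 3 is nearest to it, and the change a 32-fold higher number from compound 1 to compound 3 (1.50 log units; beyond the scatter) is large, while compound 2 lies furthest away. Compound 4 `c1ccc(-c2cc(-c3ccoc3)cc(-c3ccccn3)n2)nc1` differs from compound 1 in one place: furan-3-yl in place of thiophen-3-yl on an aromatic carbon. Within the data shown here, no measured step touches the thiophen-3-yl group itself; the only measured step, from compound 1 to compound 3, changes a pyridin-2-yl group instead, so it does not bear directly on this change. Among the measured compounds shown here, with no comparable step available, a modest shift is expected, more likely toward a higher number than a lower one. Compound 4 is therefore estimated at 0.005 ug/mL (range 0.0015 ug/mL to 0.02 ug/mL), which would mean a step of a 2.9-fold higher number from compound 1 to compound 4 (0.47 log units; beyond the scatter) in this assay.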

Compound 4, concentration for 50% growth inhibition: 0.0044 ug/mL
The estimate for compound 4 lay 1.1-fold (0.06 log units) above the measured number; low and high end bracket the measured number.
By their numbers in this assay, from the lowest: compound 1; then compound 4; then compound 3; then compound 2.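

Among these compounds, this is the first measured change at the thiophen-3-yl position: furan-3-yl, which swaps the ring's sulfur for oxygen, gives a 2.6-fold higher number from compound 1 to compound 4 (0.41 log units; beyond the scatter) in this assay. The step is modest and smaller than a 32-fold higher number from compound 1 to compound 3 (1.50 log units; beyond the scatter), which changes the pyridin-2-yl group, so this position keeps much of the growth inhibition with this swap. Nothing available explains why the number rises with this change. The compounds shown leave open how this position responds to groups other than five-membered aromatic rings, such as a phenyl ring, an amine or a longer chain.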